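Hydrazone aryl swap on a triazine sulfonamide scaffold

The compounds below may be only part of what the source reports. "The series", "measured", "known", "first", "only" and "open" are said of these compounds alone.

Measured compounds:
compound 1, `NS(=O)(=O)c1ccc(Nc2nc(N/N=C/c3ccc(C(F)(F)F)cc3)nc(Nc3ccccc3)n2)cc1`, 2420 nM
compound 2, `Cc1nn(-c2ccccc2)cc1/C=N/Nc1nc(Nc2ccccc2)nc(Nc2ccc(S(N)(=O)=O)cc2)n1`, 2500 nM

In a functional assay on UACC-257 cells (Homo sapiens) for inhibition, read by sulforhodamine B assay, with a stated time of 48 h (on this read-out higher numbers stand for weaker inhibition of growth and lower numbers for stronger inhibition of growth), compound 1 gives 2420 nM, and compound 2 gives 2500 nM. Of these two numbers compound 2 has the higher one, but the gap between them is a 1.0-fold higher number from compound 1 to compound 2 (0.01 log units; within the scatter), so the two compounds cannot be separated on this read-out.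

Compound 3, `NS(=O)(=O)c1ccc(Nc2nc(N/N=C/c3ccccn3)nc(Nc3ccccc3)n2)cc1`, has not yet been measured in this assay. It differs from compound 2 in one place: pyridin-2-yl in place of 3-methyl-1-phenyl-1H-pyrazol-4-yl on a carbon with a double bond to nitrogen. Going by the values given here, the only measured step that bears on this change is the one at the same position, the swap of the aryl group on the carbon with a double bond to nitrogen, which gave a 1.0-fold higher number from compound 1 to compound 2 (0.01 log units; within the scatter). That step shows this position tolerating an exchange of aryl group without a shift beyond the scatter, though it is a single observation and pyridin-2-yl was not among the groups tried.

On this basis compound 3 is expected to stay close to compound 2 in this assay, with a step of no change at the digits printed from compound 2 to compound 3 (within the scatter). The estimate for compound 3 is 2500 nM, with a range from 1000 nM to 6500 nM.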

Compound 3, concentration for 50% growth inhibition: 2140 nM
For compound 3 the middle estimate is 1.2-fold (0.07 log units) above the measured one, and the stated range covers the measured number.
By their numbers in this assay, from the lowest: compounds 3, 1 and 2 (each within the scatter of the next).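

In this assay the position on a carbon with a double bond to nitrogen now accepts a third aryl group without leaving the scatter: pyridin-2-yl gives a 1.2-fold lower number from compound 2 to compound 3 (0.07 log units; within the scatter) and, against the other earlier compound, a 1.1-fold lower number from compound 1 to compound 3 (0.05 log units; within the scatter). This extends the earlier tolerance to a much smaller group, since the 3-methyl-1-phenyl-1H-pyrazol-4-yl that leaves has 12 heavy atoms in two aromatic rings and the pyridin-2-yl that enters has 6 in one, and neither that difference nor the exchange of 4-(trifluoromethyl)phenyl for a ring with a hetero atom separates the compounds on this read-out. No independent measurement is available to explain why the three compounds cannot be told apart.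

All three groups at this position are aromatic rings, so the compounds leave open whether a plain alkyl chain, a cyclohexyl ring or a phenyl ring carrying a carboxylic acid or an amine would also stay within the scatter. On these data alone, the phenyl amine and the benzenesulfonamide stay the same throughout, so what changes there would do to growth inhibition also remains open.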